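Dimethylamino in place of fluoro: from compound 2 to compound 3

This account rests on a few compounds, and the source may have more. Where it says the series, first, only, none or still open, it means among the compounds named here.

Of the compounds shown here, two sharing one core have been measured in a functional assay on BT-549 cells (Homo sapiens) for inhibition; a lower number here means a stronger inhibitor of growth, a higher number a weaker inhibitor of growth. Compound 1 `COc1cc(/C=C/c2ccc(S(N)(=O)=O)cc2)cc(OC)c1` gives 10700 nM in this assay. Going by the values given here, compound 2 `NS(=O)(=O)c1ccc(/C=C/c2ccc(F)cc2)cc1` gives 205 nM in this assay, the lower of the two numbers, and the gap to compound 1, its only comparison, is far beyond the usual scatter, so compound 2 stands as the stronger inhibitor of growth of the pair.

Compound 3 `CN(C)c1ccc(/C=C/c2ccc(S(N)(=O)=O)cc2)cc1` has not yet been measured. It differs from compound 2 in a single place: dimethylamino in place of fluoro on an aromatic carbon. The new group sits on an aromatic carbon of a six-membered aromatic ring of carbon only, para to a large group, where the fluoro stood before.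

Among the compounds with values here, no pair of measured compounds follows this particular change, so its effect can only be estimated. The step of a 1.7-fold lower number from compound 2 to compound 3 (0.23 log units; within the scatter) is expected to be modest, in the direction of stronger inhibition, and may well fall within the scatter. Compound 3 is therefore expected to give about 120 nM in this assay, within a range from 30 nM to 600 nM.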

Compound 3, concentration for 50% growth inhibition: 2140 nM
Compound 3: middle estimate off by 18-fold (1.25 log units), on the low side; measured number outside the range, above it.
By their numbers in this assay, from the lowest: compound 2; then compound 3; then compound 1.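

In this assay, dimethylamino in place of fluoro on this aromatic carbon, para to a large group, gives a 10-fold higher number from compound 2 to compound 3 (1.02 log units; beyond the scatter), a large step beyond the scatter and towards weaker inhibition of growth. Compound 1 and compound 2 differ in more than one place, so the gap between them could not be assigned to any single site, whereas this pair ties a large change in the number to this one position and shows that the result depends strongly on the group placed there, with fluoro the better of the two groups tried. Nothing shown here bears on why the exchange weakens inhibition.

As far as these compounds go, two groups on one carbon do not make a trend, so it remains open where a primary amine, a methoxy group or a chlorine on the same carbon would fall relative to fluoro and dimethylamino. From the compounds shown here alone, it is also open whether fluoro itself adds to inhibition or dimethylamino alone takes away from it, a question that a plain hydrogen on that carbon would help to settle.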